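The source may report more compounds than this note shows. Statements on the series, on what has been measured and on what is new or still open speak of the compounds shown alone.

Values so far from a physicochemical assay for solubility, using the shake flask method, in phosphate buffer, measured as kinetic solubility, with a stated time of 20 h, at pH 6.5; a lower number here means a less soluble compound, a higher number a more soluble compound:

- compound 1 `FC(F)(F)c1ccc(Nc2cc3[nH]c(-c4cccc(C(F)(F)F)c4)nc3cn2)nc1` gives < 5000 nM (a limit of the assay, not a number)
- compound 2 `FC1(F)CCC(c2nc3cnc(Nc4ccc(C(F)(F)F)cn4)cc3[nH]2)C1` gives 120000 nM (a number)
- compound 3 `FC(F)(F)c1ccc(Nc2cc3[nH]c(C4CCOC4)nc3cn2)nc1` gives 166000 nM (a number)

Compound 3 (166000 nM) cannot be told apart from compound 2 (120000 nM) within the scatter. Compound 4 `FC(F)(F)c1ccc(Nc2cc3[nH]c(C4CC4)nc3cn2)nc1` carries cyclopropyl in place of oxolan-3-yl on an aromatic carbon between two ring nitrogen atoms cyclopropyl in place of oxolan-3-yl on an aromatic carbon and keeps the rest of compound 3.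

The steps of an at least 24-fold higher number from compound 1 to compound 2 (1.38 log units; beyond the scatter) and an at least 33-fold higher number from compound 1 to compound 3 (1.52 log units; beyond the scatter) are large, but both take away 3-(trifluoromethyl)phenyl, which compound 3 no longer carries, so they say little about the present change. The closest guide is a 1.4-fold higher number from compound 2 to compound 3 (0.14 log units; within the scatter) (one non-aromatic ring exchanged for another at the same place). Among the compounds with values here, that is a single pair, and no measured compound carries cyclopropyl. In this assay compound 4 is therefore expected to stay with compound 3 and compound 2, with no step beyond the scatter in either direction. The estimated step is a 1.5-fold lower number from compound 3 to compound 4 (0.18 log units; within the scatter) on this reading. For compound 4 the estimated value is 110000 nM with an expected range from 40000 nM to 250000 nM as the working figure.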

Compound 4, solubility: < 5000 nM
Compound 4 ended at the assay's limit; the forecaster's own chance of this, stated with the estimate: 5%; middle value at least 22-fold (1.34 log units) from the limit.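

In this assay, an exchange of one non-aromatic ring for another at this place is not always as quiet as a 1.4-fold higher number from compound 2 to compound 3 (0.14 log units; within the scatter) suggested: cyclopropyl on the aromatic carbon between two ring nitrogen atoms gives an at least 33-fold lower number from compound 3 to compound 4 (1.52 log units; beyond the scatter), and likewise an at least 24-fold lower number from compound 2 to compound 4 (1.38 log units; beyond the scatter), and compound 2 has no ring oxygen, so the oxygen of oxolan-3-yl alone does not mark the difference. Compound 4 gives < 5000 nM, which is a limit of the assay and not a number, so a non-aromatic ring at this place does not by itself keep a compound off that limit. The step between compound 1 and compound 4 cannot be read, because both values are limits: the limit of < 5000 nM in this assay, at which 2 of the 4 values shown sit.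

With only three non-aromatic rings shown at this place, it stays open whether the separation follows ring size, the count of heavy atoms, or something particular to cyclopropyl. A cyclobutyl ring, an open chain such as isopropyl, or a longer chain ending in an amine at the same carbon would show where between cyclopropyl and the two five-membered rings the values part.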